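Aryl change on the saturated ring carbon: compound 3 to compound 4

The source may hold more compounds than are shown below. What is called first, only, known or untested is meant among the compounds shown, and "the series" means these compounds.

Measured so far:
Compound 1, `COc1cc(/C=C/C(=O)C2=C(/C=C/c3ccc(O)c(OC)c3)NC(=O)NC2c2ccccc2O)ccc1O`; in a functional assay, with a stated time of 20 min, tested at 50 uM (on this read-out lower numbers stand for a weaker effect and higher numbers for a stronger effect at the one concentration tested), compound 1 gives 88.9%.
Compound 2, `COc1cc(/C=C/C(=O)C2=C(/C=C/c3ccc(O)c(OC)c3)NC(=O)NC2c2cccc([N+](=O)[O-])c2)ccc1O`; in this assay compound 2 gives 71%.
Compound 3, `COc1cc(/C=C/C(=O)C2=C(/C=C/c3ccc(O)c(OC)c3)NC(=S)NC2c2ccc(C)cc2)ccc1O`; in this assay compound 3 gives 62%.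

Compound 3 holds the lowest of the three numbers, but its gap to compound 2 lies within the scatter; only its gap to compound 1 lies beyond it. Compound 4, `COc1cc(/C=C/C(=O)C2=C(/C=C/c3ccc(O)c(OC)c3)NC(=S)NC2c2c(Cl)cccc2Cl)ccc1O`, is not yet measured. It differs from compound 3 by 2,6-dichlorophenyl in place of 4-methylphenyl on a saturated ring carbon. For the measured compounds named here, the one measured step that touches the same place is the aryl swap on the saturated ring carbon, a number 17.9 percentage points lower from compound 1 to compound 2 (beyond the scatter), a modest drop. Compound 2 and compound 3 differ in two places, so their values are only read side by side. One step of modest size is a thin basis; a step of similar, modest size is expected in this assay for compound 4, most likely downward but not clearly beyond the scatter. Compound 4 is therefore estimated at 55%, with a range from 35% to 75%. This estimate for compound 4 means an expected step of a number 7 percentage points lower from compound 3 to compound 4 (within the scatter).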

Compound 4, a percentage reported as activity, at one concentration (the size of the read-out at that concentration, not a potency): 50.2%
Compound 4: middle estimate off by 4.8 percentage points, on the high side; the range from low to high includes it.
By their numbers in this assay, from the lowest: compound 4; then compounds 3 and 2 (each within the scatter of the next); then compound 1.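

In this assay, the change to 2,6-dichlorophenyl from 4-methylphenyl gives a number 11.8 percentage points lower from compound 3 to compound 4 (beyond the scatter). The aryl group on the saturated ring carbon therefore moves the read-out beyond the scatter in compounds carrying a thiocarbonyl, whereas the earlier step at this position, a number 17.9 percentage points lower from compound 1 to compound 2 (beyond the scatter), came from compounds carrying a carbonyl. The new drop also occurs between two aryl groups that both count no hydrogen-bond donors or acceptors, and nothing available accounts for its direction or size.

Open, going by these compounds, is whether the two chlorines act together or one alone would give the same step, and how a 2-hydroxyphenyl group behaves alongside the thiocarbonyl. On these data alone, the effect on this read-out of an amine or a carboxylic acid on the aryl ring also remains unknown.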